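The source may report more compounds than this note shows. Statements on the series, on what has been measured and on what is new or still open speak of the compounds shown alone.

Working notes on the series. Two analogues on the shared core have been measured so far: compound 1 `c1ccc(NN=C(c2nc3ccccc3[nH]2)c2nc3ccccc3[nH]2)cc1` and compound 2 `Clc1ccc(NN=C(c2nc3ccccc3[nH]2)c2nc3ccccc3[nH]2)cc1`. In a functional assay on U-118-MG cells (Homo sapiens) for cytotoxicity, read by MTT assay, with a stated time of 72 h (on this read-out lower numbers stand for stronger inhibition and higher numbers for weaker inhibition), compound 1 gives 160000 nM, and in this assay compound 2 gives 250000 nM. For the measured compounds named here, the one step between them, a 1.6-fold higher number from compound 1 to compound 2 (0.19 log units; within the scatter), does not rise above the scatter of repeated runs. Going by the values given here, compound 2 therefore carries the higher of the two numbers on record, with compound 1 as its only neighbour, and the two cannot be ordered against each other.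

The next compound, compound 3 `O=[N+]([O-])c1ccc(NN=C(c2nc3ccccc3[nH]2)c2nc3ccccc3[nH]2)cc1`, differs from compound 2 in one place: nitro in place of chloro on an aromatic carbon. Among the compounds with values here, the only measured step that bears on a change at this position is the one from compound 1 to compound 2, the replacement of hydrogen by chloro, and it stayed within the scatter. Within the data shown here, no measured step involves a nitro group, so nothing in the present data points to a shift in either direction. For compound 3 the expectation in this assay is accordingly a step of a 1.3-fold lower number from compound 2 to compound 3 (0.10 log units; within the scatter), that is, no change beyond the scatter, with the estimate for compound 3 set at 200000 nM, in the range 80000 nM to 500000 nM.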

Compound 3, half-maximal inhibitory concentration: 250000 nM
The estimate for compound 3 lay 1.3-fold (0.10 log units) below the measured number; the range from low to high includes it.
By their numbers in this assay, from the lowest: compounds 1, 2 and 3 (each within the scatter of the next).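

In this assay the step of nitro in place of chloro, no change at the digits printed from compound 2 to compound 3 (within the scatter), stays within the scatter, and so does the step of nitro in place of hydrogen, a 1.6-fold higher number from compound 1 to compound 3 (0.19 log units; within the scatter), so compound 3 cannot be ordered against either neighbour. Until now this position rested on a single replacement, chloro for hydrogen; it now has a second, in which a group of 3 heavy atoms with 2 hydrogen-bond acceptors enters, and across compounds 1, 2 and 3 none of the changes at this position moves the number beyond the scatter. Nothing on hand gives a reason for this lack of separation between the three compounds.

On these data alone, whether a different kind of group at the same place, such as an amine or a carboxylic acid, would shift the number beyond the scatter remains open. Also open, as far as these compounds go, is whether a change elsewhere on the shared core, for example a longer chain on one of the ring nitrogens, would separate compounds in a way that these three do not.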